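A few compounds are considered here, and "the series" means these few. Any claim that something is new, unique, unknown or untested is made for them only; others in the source may bear on it.

Compound 1 `N=C(N)c1ccc(/N=N/Nc2ccccc2C#Cc2ccccc2)cc1` gives 5100 nM in a functional assay on MDA-MB-231 cells (Homo sapiens) for antiproliferative activity, read by WST assay, with a stated time of 72 h; a lower number here means a stronger inhibitor of growth, a higher number a weaker inhibitor of growth.
Compound 2 `N=C(N)c1ccc(/N=N/Nc2cccc(C#Cc3ccccc3)c2)cc1` gives 9500 nM in this assay.
Compound 3 `N=C(N)c1ccc(/N=N/Nc2ccccc2C#Cc2ccc(F)cc2)cc1` gives 6200 nM in this assay.

Compound 4 `N=C(N)c1ccc(/N=N/Nc2cccc(C#Cc3ccc(F)cc3)c2)cc1` has not yet been tested. Compound 1 and compound 2 are built from the same atoms joined differently; the difference between the two cores is not broken down here. Compound 3 comes from compound 1 by one change, (fluoro in place of hydrogen on an aromatic carbon), and that change made a 1.2-fold higher number from compound 1 to compound 3 (0.08 log units; within the scatter). Compound 4 comes from compound 2 by the same change, (fluoro in place of hydrogen on an aromatic carbon), at a place described in the same words. Because the same change gave a 1.2-fold higher number from compound 1 to compound 3 (0.08 log units; within the scatter), the step to compound 4 is expected to be of similar, small size, a 1.1-fold higher number from compound 2 to compound 4 (0.04 log units; within the scatter). Compound 4 is therefore estimated at 10500 nM, most likely falling between 5000 nM and 22000 nM.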

Compound 4, concentration for 50% growth inhibition: 5500 nM
Compound 4: the middle estimate sits 1.9-fold (0.28 log units) above what was measured; the measured number falls inside the stated range.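

On the core of compound 2, going from phenyl to 4-fluorophenyl gives a 1.7-fold lower number from compound 2 to compound 4 (0.24 log units; within the scatter) in this assay. Set beside the same change on the core of compound 1, the two steps agree as far as such numbers can tell: the same change on two cores in this assay, a 1.2-fold higher number (0.08 log units; within the scatter) from compound 1 to compound 3 and a 1.7-fold lower number (0.24 log units; within the scatter) from compound 2 to compound 4, 2.1-fold (0.32 log units) apart, within the scatter of two such steps

So on both cores the fluoro leaves the number within the usual scatter, but this does not show that it helps or harms growth inhibition, or that the two cores answer to it differently.

The compounds shown leave open whether a different group at that place, such as chloro, methoxy, an amine or a carboxylic acid, would give a step beyond the scatter.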